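Swapping 4-Methoxyphenyl for 2-Methylphenyl on the Sulfonamide Nitrogen

The source may hold more compounds than are shown below. What is called first, only, known or untested is meant among the compounds shown, and "the series" means these compounds.

Measured so far in a functional assay on MCF7 cells (Homo sapiens) for antiproliferative activity, read by sulforhodamine B assay, with a stated time of 48 h; on this read-out higher numbers stand for weaker inhibition and lower numbers for stronger inhibition:
- compound 1 `CCc1ccccc1NS(=O)(=O)c1ccc(N2CCNC2=O)cc1`: 350 nM
- compound 2 `O=C1NCCN1c1ccc(S(=O)(=O)Nc2ccc(Cl)cc2)cc1`: 170 nM
- compound 3 `COc1ccc(NS(=O)(=O)c2ccc(N3CCNC3=O)cc2)cc1`: > 1000 nM

Compound 3 gives > 1000 nM, which is a limit of the assay and not a number. Both steps leading to it are beyond the scatter, so compound 3 is the weakest of the three.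

The next compound, compound 4 `Cc1ccccc1NS(=O)(=O)c1ccc(N2CCNC2=O)cc1`, puts 2-methylphenyl in place of 4-methoxyphenyl on a sulfonamide nitrogen. The counted difference is 2-methylphenyl in place of 4-methoxyphenyl on a sulfonamide nitrogen.

The measured group nearest to 2-methylphenyl is the 2-ethylphenyl of compound 1, which gives 350 nM. Read backwards, an at least 2.8-fold higher number from compound 1 to compound 3 (0.45 log units; beyond the scatter) suggests that leaving 4-methoxyphenyl for such a group should lower the number. The other step into the limit, an at least 5.8-fold higher number from compound 2 to compound 3 (0.76 log units; beyond the scatter), also leaves 4-methoxyphenyl on the weak side. Only a limit anchors the starting point, so the size of the change stays uncertain, but a drop beyond the scatter is expected in this assay.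

The estimated step is an at least 2.5-fold lower number from compound 3 to compound 4 (0.39 log units; beyond the scatter).

For compound 4 the expected value is 400 nM, with an estimated range from 150 nM to 1000 nM.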

Compound 4, half-maximal inhibitory concentration: 280 nM
Compound 4: middle estimate off by 1.4-fold (0.15 log units), on the high side, and the stated range covers the measured number.
By their numbers in this assay, from the lowest: compounds 2, 4 and 1 (each within the scatter of the next, the first and the last beyond it). At a limit, above all of these: compound 3.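

In this assay the change from 4-methoxyphenyl to 2-methylphenyl on the sulfonamide nitrogen gives an at least 3.5-fold lower number from compound 3 to compound 4 (0.55 log units; beyond the scatter) and so shows that a group of the same ring type can leave the weak end of this series. Among these compounds, the new compound does not separate from the other two groups, since a 1.3-fold lower number from compound 1 to compound 4 (0.10 log units; within the scatter) and a 1.6-fold higher number from compound 2 to compound 4 (0.22 log units; within the scatter) both lie within the scatter, which leaves 4-methoxyphenyl as the only one of the four groups that stands apart. The true size of the first step stays unknown because compound 3 gives only a limit and not a number: the limit of > 1000 nM in this assay, at which 1 of the 4 values shown sits.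

The compounds shown leave open whether a plain phenyl, or a 2-methoxyphenyl that carries the same methoxy group at the other ring position named by 2-methylphenyl, would stay with compound 4 or fall with compound 3. They also leave open what a ring bearing an amine or a carboxylic acid would do at this nitrogen, and whether a longer chain than the 2-ethylphenyl of compound 1 would still fit this group of close values.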